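The source may report more compounds than this note shows. Statements on the series, on what has been measured and on what is new or still open speak of the compounds shown alone.

In an assay on isolated protein for inhibition of high affinity nerve growth factor receptor (Homo sapiens), read by 33P incorporation (a higher number here means a weaker inhibitor, a lower number a stronger inhibitor), compound 3 `Nc1cccc(-c2cnc3[nH]cc(-c4ccncc4)c3c2)c1` gives 42.7 nM, the highest number of the three measured compounds. Compound 1 `Nc1cc(NS(=O)(=O)c2ccccc2)cc(-c2cnc3[nH]cc(-c4ccncc4)c3c2)c1` gives 9.4 nM in this assay, and compound 2 `CC(=O)Nc1cc(N)cc(-c2cnc3[nH]cc(-c4ccncc4)c3c2)c1` gives 5.41 nM. The change from compound 3 to compound 4 `CS(=O)(=O)Nc1cc(N)cc(-c2cnc3[nH]cc(-c4ccncc4)c3c2)c1` is methanesulfonamido in place of hydrogen on an aromatic carbon. Among the compounds with values here, two measured steps bear on it, both running in the opposite direction: a 4.5-fold higher number from compound 1 to compound 3 (0.66 log units; beyond the scatter), and a 7.9-fold higher number from compound 2 to compound 3 (0.90 log units; beyond the scatter). Both steps remove a nitrogen-linked acyl or sulfonyl group from the same ring position that compound 4 fills with methanesulfonamido, and in each case the number rose beyond the scatter. The methanesulfonamido group of compound 4 lies between the phenylsulfonylamino of compound 1 and the acetamido of compound 2 in kind, so a fall of similar size is expected. For compound 4 the expectation in this assay is a 6.1-fold lower number from compound 3 to compound 4 (0.79 log units; beyond the scatter) to an estimated 7 nM, within a range of 3 nM to 20 nM.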

Compound 4, half-maximal inhibitory concentration: 33.8 nM
Estimate against measurement, compound 4: 4.8-fold (0.68 log units) below, and the stated range ends below it.
By their numbers in this assay, from the lowest: compounds 2 and 1 (each within the scatter of the next); then compounds 4 and 3 (each within the scatter of the next).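

In this assay the step of a 1.3-fold lower number from compound 3 to compound 4 (0.10 log units; within the scatter) shows that filling this aromatic carbon with a nitrogen-linked sulfonyl group does not by itself bring the number down. What stands on that nitrogen matters, as methylsulfonyl in place of acetyl gives a 6.2-fold higher number from compound 2 to compound 4 (0.80 log units; beyond the scatter) and methyl in place of phenyl on the sulfonyl sulfur gives a 3.6-fold higher number from compound 1 to compound 4 (0.56 log units; beyond the scatter), so the two sulfonamides, compound 1 and compound 4, do not behave alike at this position. Nothing shown here explains these differences.

As far as these compounds go, it remains open whether the result for compound 4 is particular to methyl on the sulfonyl sulfur or would also hold for an ethyl or a cyclopropyl there. Also open, from the compounds shown here alone, is what a urea or a propionyl group on the same nitrogen would give.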